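Catechol benzylamines as arginase-1 inhibitors: dropping the methoxy

The compounds below may be only part of what the source reports. "The series", "measured", "known", "first", "only" and "open" are said of these compounds alone.

The series is followed in an assay on liver for inhibition of arginase-1 (Bos taurus), with a stated time of 60 min; a higher number here means a weaker inhibitor, a lower number a stronger inhibitor. Compound 1 `COc1cccc(NCc2ccc(O)c(O)c2)c1` gives 185000 nM. Compound 2 `COc1cccc(CNCc2ccc(O)c(O)c2)c1` gives 300000 nM, a number within the scatter of compound 1, so no order between these two can be read. Compound 3 `N=C(NO)NCC[C@H](N)C(=O)O` gives 2700 nM, a far lower number than that of compound 1 and beyond the scatter; compound 1 thus stands second highest of the three. Compound 4 `Oc1ccc(CNc2ccccc2)cc1O` differs from compound 1 by hydrogen in place of methoxy on an aromatic carbon. Among the compounds with values here, no measured pair shows this change, so its size is unknown. The step is expected to be a 1.1-fold higher number from compound 1 to compound 4 (0.03 log units; within the scatter), not beyond the scatter in either direction. Compound 4 is accordingly estimated at 200000 nM, within a range from 90000 nM to 450000 nM.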

Compound 4, half-maximal inhibitory concentration: 164000 nM
Compound 4: middle estimate off by 1.2-fold (0.09 log units), on the high side, within the range that was stated.
By their numbers in this assay, from the lowest: compound 3; then compounds 4, 1 and 2 (each within the scatter of the next).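

In this assay, hydrogen in place of methoxy on an aromatic carbon gives a 1.1-fold lower number from compound 1 to compound 4 (0.05 log units; within the scatter), the first step read at this position. The methoxy is therefore not needed to hold the number of compound 1, and the step gives no order between the two compounds. No separate measurement bears on this result.

Open, going by these compounds, is whether an amine or a carboxylic acid at this place would shift the number beyond the scatter. Also open, on these data alone, is whether the same change on the core of compound 2 would give a similar step.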